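Working notes on four analogues around a shared core

The compounds below may be only part of what the source reports. "The series", "measured", "known", "first", "only" and "open" are said of these compounds alone.

Compound 1 `CCC/C=C/C(=O)Nc1cccc(Oc2nc(Nc3ccn(C)n3)nc3c2CSCC3)c1` is the reference of the set. In a functional assay on MCF7 cells (Homo sapiens) for antiproliferative activity, read by MTT assay, with a stated time of 72 h (a lower number here means a stronger inhibitor, a higher number a weaker inhibitor), compound 1 gives 22600 nM. Compound 2 `CC(C)=CC(=O)Nc1cccc(Oc2nc(Nc3ccn(C)n3)nc3c2CSCC3)c1` carries 2-methylprop-1-en-1-yl in place of pent-1-en-1-yl on a carbonyl carbon. In this assay compound 2 reaches only the limit > 50000 nM. The step of an at least 2.2-fold higher number from compound 1 to compound 2 (0.34 log units; beyond the scatter) is read against (the limit of > 50000 nM in this assay, at which 2 of the 3 values shown sit). Compound 3 `CCC/C=C/C(=O)Nc1cccc(Oc2nc(Nc3ccc(OC)cc3)nc3c2CSCC3)c1` differs from compound 1 in its core by 4-methoxyphenyl in place of 1-methyl-1H-pyrazol-3-yl on a nitrogen on an aromatic ring. In this assay compound 3 also sits at the limit > 50000 nM. The step of an at least 2.2-fold higher number from compound 1 to compound 3 (0.34 log units; beyond the scatter) likewise rests on (the limit of > 50000 nM in this assay, at which 2 of the 3 values shown sit). Compound 4 `COc1ccc(Nc2nc3c(c(Oc4cccc(NC(=O)C=C(C)C)c4)n2)CSCC3)cc1` is not yet measured; it combines the core of compound 3 with 2-methylprop-1-en-1-yl in place of pent-1-en-1-yl on a carbonyl carbon, the same change as from compound 1 to compound 2, since both sit on a carbonyl carbon whose other neighbours are an amide-type nitrogen. The earlier instance of this change made an at least 2.2-fold higher number from compound 1 to compound 2 (0.34 log units; beyond the scatter). For compound 4 the step is expected to be a step that the limit leaves unreadable from compound 3 to compound 4, resting on an at least 2.2-fold higher number from compound 1 to compound 2 (0.34 log units; beyond the scatter) and on the limit already reached by compound 3. Compound 4 is therefore expected at 90000 nM, within 45000 nM to 250000 nM, and most probably reported only as a limit.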

Compound 4, half-maximal inhibitory concentration: > 50000 nM
Compound 4 ended at the assay's limit; the forecaster's own chance of this, stated with the estimate: 85%; the middle value lies beyond the limit too.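

In this assay, within the data shown here, compound 4 gives > 50000 nM as a limit of the assay, so no step from compound 3 or compound 2 to compound 4 can be read: the limit of > 50000 nM in this assay, at which 3 of the 4 values shown sit. The compounds shown leave open how far compound 2, compound 3 and compound 4 lie past that limit, and whether they differ from one another at all.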